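The source may hold more compounds than are shown below. What is called first, only, known or untested is meant among the compounds shown, and "the series" means these compounds.

Compound 1, `CCc1c(-c2ccc(O)cc2)cnc(N)c1-c1ccc(O)cc1`, gives 4600 nM in an assay on isolated protein for inhibition of ubiquitin carboxyl-terminal hydrolase 7 (Homo sapiens), read by fluorescence, with a stated time of 1 h; on this read-out lower numbers stand for stronger inhibition and higher numbers for weaker inhibition.
Compound 2, `CCc1c(-c2ccc3[nH]ncc3c2)cnc(N)c1-c1ccc(O)cc1`, gives 980 nM in this assay.

Of the two measured compounds, compound 2 stands at the lower number, and its gap to compound 1 is wider than the usual scatter of repeated measurements, so compound 2 counts as the stronger inhibitor of the pair.

Compound 3, `CCc1c(-c2ccc3c(cnn3C)c2)cnc(N)c1-c1ccc(O)cc1`, has not yet been measured. It differs from compound 2 in a single place: methyl in place of hydrogen on an aromatic nitrogen. Within the data shown here, no measured pair in this set shows what such a change does, so there is no step here to lean on. Because compound 2 gives 980 nM, the expectation for compound 3 is a modest weakening, a step of a 2.0-fold higher number from compound 2 to compound 3 (0.31 log units; beyond the scatter), with a real chance that it stays within the scatter. The estimate for compound 3 in this assay is 2000 nM, with a range from 400 nM to 10000 nM.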

Compound 3, half-maximal inhibitory concentration: > 63300 nM
Compound 3: only a limit was reported; the forecaster's own chance of this, stated with the estimate: 5%; at least 31-fold (1.50 log units) between middle value and limit.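

In this assay, among these compounds, this aromatic nitrogen proves far more sensitive than the earlier compounds could reveal: methyl in place of hydrogen, a change of just one heavy atom, brings an at least 64-fold higher number from compound 2 to compound 3 (1.81 log units; beyond the scatter) and takes the series from a measured value to one that cannot be pinned down. For compound 3, > 63300 nM is a limit of the assay and not a number. The step is therefore a minimum and not a measured size: the limit of > 63300 nM in this assay, at which 1 of the 3 values shown sits.

A single pair cannot separate the loss of the hydrogen from the arrival of the methyl, so the cause of this drop stays unknown. It also leaves open how the same nitrogen would respond to a longer chain such as ethyl, or to a chain ending in an amine or a carboxylic acid.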